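Series notes: exchange on the carbonyl carbon of compound 2

The source may hold more compounds than are shown below. What is called first, only, known or untested is meant among the compounds shown, and "the series" means these compounds.

Among the measured compounds shown here, compound 2 `COc1cc(Cl)cc(-c2nn(-c3cccc(NC(=O)Nc4ccc(Cl)c(Cl)c4)c3)cc2-c2ccncc2)c1` sits at the top of the two numbers measured so far; in a functional assay on HCT-116 cells (Homo sapiens) for inhibition, read by sulforhodamine B assay, with a stated time of 48 h, tested at 0.01 uM (on this read-out higher numbers stand for a weaker effect at the one concentration tested and lower numbers for a stronger effect), compound 2 gives 105%. Its nearest neighbour is compound 1 `O=C(Nc1cccc(-n2cc(-c3ccncc3)c(-c3cc(O)cc(Cl)c3)n2)c1)Nc1ccc(Cl)c(Cl)c1`, which in this assay gives 101%. For the measured compounds named here, the one measured step, a number 4 percentage points higher from compound 1 to compound 2 (within the scatter), concerns methyl in place of hydrogen on an oxygen on an aromatic ring and stays within the scatter. Both numbers lie close to the level where the assay reports no effect at the single concentration tested.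

Compound 3 `COc1cc(Cl)cc(-c2nn(-c3cccc(NC(=O)c4cccc(C(F)(F)F)c4)c3)cc2-c2ccncc2)c1` differs from compound 2 by 3-(trifluoromethyl)phenyl in place of (3,4-dichlorophenyl)amino on a carbonyl carbon. Going by the values given here, no measured step touches the carbonyl carbon or the (3,4-dichlorophenyl)amino group, so nothing here speaks directly for or against a change in this assay. With compound 1 and compound 2 both near the no-effect level, the expectation for compound 3 is a step of a number 5 percentage points lower from compound 2 to compound 3 (within the scatter) that does not go beyond the scatter. Compound 3 is therefore estimated in this assay at 100%, with a range from 85% to 115%.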

Compound 3, a percentage reported as activity, at one concentration (the size of the read-out at that concentration, not a potency): 100%
Compound 3: middle estimate and measured number agree at the digits printed, and the stated range covers the measured number.
By their numbers in this assay, from the lowest: compounds 3, 1 and 2 (each within the scatter of the next).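

Among the compounds shown here, the exchange on the carbonyl carbon, 3-(trifluoromethyl)phenyl in place of (3,4-dichlorophenyl)amino, is the first measured change at this position and reads in this assay as a number 5 percentage points lower from compound 2 to compound 3 (within the scatter). The entering group carries no hydrogen-bond donor, whereas the leaving group carries one, and it brings fluorine in place of chlorine, yet compound 3 stays with compound 1 and compound 2 near the level of no effect, so at the one concentration tested this position shows no sensitivity to the change. No measured data on the series offer an explanation for this result, and a read-out this close to the no-effect level cannot separate the two groups.

On these data alone, it remains open whether a piperidine, a morpholine or a benzoic acid group on the same carbonyl carbon would give a number apart from these three. As far as these compounds go, it also remains open whether compound 2 and compound 3 would separate on a read-out that gives a potency rather than a single-concentration effect, since neither the urea-type nor the amide-type link is distinguished here.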